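This account rests on a few compounds, and the source may have more. Where it says the series, first, only, none or still open, it means among the compounds named here.

Measured so far in a functional assay on HepG2 cells (Homo sapiens) for cytotoxicity, with a stated time of 72 h; a lower number here means that less compound is needed, a higher number that more compound is needed for the effect:
Compound 1 `C=C[C@@](C)(/C=C/c1ccc(Nc2cc(F)cc(F)c2)cc1)CCC=C(C)C`: > 52000 nM
Compound 2 `C=C[C@@](C)(/C=C/c1ccc(Nc2ccc(Cl)c(Cl)c2)cc1)CCC=C(C)C`: > 52000 nM

Both entries are limits of the assay and not numbers. Compound 2 therefore has no exact value of its own, only the limit > 52000 nM. Compound 1 and compound 2 share that limit: the limit of > 52000 nM in this assay, at which 2 of the 2 values shown sit. For the measured compounds named here, the one measured step, which swaps 3,5-difluorophenyl for 3,4-dichlorophenyl on the nitrogen, is a step that the two limits leave unreadable from compound 1 to compound 2, so it offers no size to carry forward.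

Compound 3 `C=C[C@@](C)(/C=C/c1ccc(-c2cccc(Br)c2)cc1)CCC=C(C)C` has not yet been measured. It differs from compound 2 as follows: 3-bromophenyl in place of (3,4-dichlorophenyl)amino on an aromatic carbon. The 3-bromophenyl enters in place of (3,4-dichlorophenyl)amino, para to a large group.

With no readable step as a guide, no direction can be forecast, and another limit is the likeliest result in this assay. The expected change is a step that the limit leaves unreadable from compound 2 to compound 3. For compound 3 the estimate is 55000 nM, with an expected range of 25000 nM to 110000 nM.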

Compound 3, half-maximal effective concentration: > 52000 nM
Compound 3: only a limit was reported; the forecaster's own chance of this, stated with the estimate: 75%; the middle value does not contradict the limit.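

For the compounds shown here, no step among compound 1, compound 2 and compound 3 can be read, and all three stop at the same assay limit: the limit of > 52000 nM in this assay, at which 3 of the 3 values shown sit. The compounds shown leave open whether these swaps change the concentration needed in this assay at all, and by how much.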